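An Aryl Swap That Keeps the Bromo

The source may hold more compounds than are shown below. What is called first, only, known or untested is meant among the compounds shown, and "the series" means these compounds.

In a physicochemical assay, with a stated time of 6 min (a higher number here means a weaker inhibitor, a lower number a stronger inhibitor), compound 2 `O=C(Nc1ccc([N+](=O)[O-])cc1)Nc1nc(-c2cc3cc(Br)ccc3o2)cs1` gives > 200000 nM, which is a limit of the assay and not a number.

Compound 4 `COc1cccc(NC(=O)Nc2nc(-c3cc4cc(Br)ccc4o3)cs2)c1` has not yet been measured. It differs from compound 2 in one place: 3-methoxyphenyl in place of 4-nitrophenyl on an amide-type nitrogen. In words, 3-methoxyphenyl stands in place of 4-nitrophenyl on an amide-type nitrogen.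

Going by the values given here, only one measured step starts from compound 2. Hydrogen in place of bromo on an aromatic carbon gives an at least 10-fold lower number from compound 2 to compound 3 (1.01 log units; beyond the scatter), a large step, but it leaves the 4-nitrophenyl group untouched and so says nothing directly about this swap. Compound 4 keeps the bromo, so it is not expected to come close to compound 3 `O=C(Nc1ccc([N+](=O)[O-])cc1)Nc1nc(-c2cc3ccccc3o2)cs1` at 19300 nM. Compound 1 `COc1ccc(NC(=O)Nc2nc(-c3cc4cc([N+](=O)[O-])ccc4o3)cs2)cc1` also carries a methoxy group and gives 121000 nM in this assay, but it differs from compound 2 in more than one place and offers only a loose guide.

A small step is therefore expected, towards a lower number if it shows at all, and the assay may again report only a limit. The expected change is an at least 1.6-fold lower number from compound 2 to compound 4 (0.22 log units; that floor lies within the scatter). For compound 4 the estimate is 120000 nM, with an expected range from 40000 nM to 300000 nM.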

Compound 4, half-maximal inhibitory concentration: > 200000 nM
Compound 4 ended at the assay's limit; the forecaster's own chance of this, stated with the estimate: 40%; at least 1.6-fold (0.22 log units) between middle value and limit.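

In this assay compound 4 gives > 200000 nM as a limit of the assay and not a number. Compound 2 also stands at a limit, and the step from compound 2 to compound 4 cannot be read. The compounds shown leave open whether 3-methoxyphenyl in place of 4-nitrophenyl on an amide-type nitrogen changes the number at all.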